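Adding a Hydroxymethyl Group to Compound 2

A few compounds are considered here, and "the series" means these few. Any claim that something is new, unique, unknown or untested is made for them only; others in the source may bear on it.

In a functional assay on MCF7 cells (Homo sapiens) for inhibition, read by MTT assay, with a stated time of 72 h, tested at 50 uM (a higher number here means more inhibition of growth at the concentration tested, a lower number less inhibition of growth), compound 1 `C=CCc1ccc(OCc2cn(-c3cccc([N+](=O)[O-])c3)nn2)c(O)c1` gives 56.5% and compound 2 `C=CCc1cc(O)c(O)c(CN2CCC(C)CC2)c1` gives 54.2%. These two numbers lie within the usual scatter of each other, so compound 2 stands level with compound 1. Compound 3 `C=CCc1cc(O)c(O)c(CN2CCC(CCO)CC2)c1` differs from compound 2 in one place: hydroxymethyl in place of hydrogen on a saturated chain carbon bound to a saturated ring carbon, with hydroxymethyl in place of hydrogen on a saturated chain carbon bound to a saturated ring carbon. Among the compounds with values here, no measured pair shows this kind of change, and no step beyond the scatter is expected in this assay. The estimated change is a number 4.2 percentage points lower from compound 2 to compound 3 (within the scatter). For compound 3 the expected value is 50%, within a range from 34% to 66%.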

Compound 3, percent growth inhibition at one concentration: 33.3%
Beside the measured number, compound 3's estimate is 16.7 percentage points above it; the measured number lies below the stated range.
By their numbers in this assay, from the lowest: compound 3; then compounds 2 and 1 (each within the scatter of the next).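

Within the data shown here, at this saturated chain carbon bound to a saturated ring carbon, going from methyl to 2-hydroxyethyl in this assay gives a number 20.9 percentage points lower from compound 2 to compound 3 (beyond the scatter) and so is the first step here to lie beyond the scatter. The position therefore does respond to a change in what it carries, at least for this one pair. No evidence at hand accounts for this loss of growth inhibition. Still open, on these data alone, is whether the hydroxyl or the added chain length matters more. An ethyl group, a longer chain or a carboxylic acid at this place would help separate the two.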